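The source may report more compounds than this note shows. Statements on the series, on what has been measured and on what is new or still open speak of the compounds shown alone.

Measured so far:
- compound 1, `Cc1c(Br)sc(N)c1C(=O)c1ccc(Cl)cc1`: 1%
- compound 2, `CC(C)(C)Cc1c(-c2ccc(Cl)c(Cl)c2)sc(N)c1C(=O)c1ccc(Cl)cc1`: 1%
- compound 3, `COc1ccc(-c2sc(N)c(C(=O)c3cccc(Cl)c3)c2CC(C)(C)C)cc1`: 2%

All three numbers come from an assay on CHO cells for displacement of a labelled ligand from adenosine receptor A3 (Homo sapiens), read by scintillation counting, tested at 10 uM; on this read-out higher numbers stand for more inhibition at the one concentration tested (going by the name of the read-out) and lower numbers for less inhibition. In this assay compound 2 gives 1%, level at the digits printed with compound 1, which gives 1%; compound 3 gives 2%, within the scatter of compound 2. Going by the values given here, the three measured compounds therefore sit together near the bottom of the read-out, and no pair among them differs beyond the scatter, so the series so far shows no step on which to rest an expectation.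

The next compound, compound 4, is `CC(C)(C)Cc1c(-c2cn[nH]c2)sc(N)c1C(=O)c1ccc(Cl)cc1`. It is obtained from compound 2 by a single change on the shared core: 1H-pyrazol-4-yl in place of 3,4-dichlorophenyl on an aromatic carbon. Among the compounds with values here, nothing measured here speaks to what this change does; the only guide is the flat, low level of compounds 1, 2 and 3. On that basis the step of a number 4 percentage points higher from compound 2 to compound 4 (within the scatter) is expected to stay within the scatter, with no direction assigned. For compound 4 in this assay the estimate is 5%, with a range from -6% to 20% expected to cover most repeat measurements.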

Compound 4, a percentage reported as inhibition, at one concentration (the size of the read-out at that concentration, not a potency): 1%
Compound 4: middle estimate off by 4 percentage points, on the high side; measured number inside the range.
By their numbers in this assay, from the lowest: compounds 1, 2, 4 and 3 (each within the scatter of the next).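

In this assay, 1H-pyrazol-4-yl in place of 3,4-dichlorophenyl, on the aromatic carbon next to the ring sulfur, gives no change at the digits printed from compound 2 to compound 4 (within the scatter), the first step read at this position. With the neopentyl group and the (4-chlorophenyl)carbonyl group held constant, the read-out does not separate a six-membered carbon-only aromatic ring bearing chlorine from a five-membered aromatic ring with 2 hetero atoms, a hydrogen-bond donor and a hydrogen-bond acceptor, though both values lie so near the bottom of the read-out that this step cannot show whether either group matters to the receptor at all. Nothing available here bears on why the two groups read alike.

Still open, from the compounds shown here alone, is whether any other group at this position, such as a carboxylic acid or an aminomethyl group, would lift the number clear of the scatter, or whether the position stays silent whatever it carries. Equally open, going by these compounds, is whether changes elsewhere on the shared core, such as a longer chain in place of neopentyl or an acetyl group on the amino nitrogen, would move the read-out at all.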